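The compounds below may be only part of what the source reports. "The series", "measured", "known", "first", "only" and "open" are said of these compounds alone.

Measured compounds:
- compound 1, `Cc1nc(-c2cccc(CN(C)c3ccc4[nH]nc(C(=O)O)c4c3)c2)sc1C`: 290 nM
- compound 2, `CNc1ccc2[nH]nc(C(=O)O)c2c1`: > 30000 nM

Compound 1, `Cc1nc(-c2cccc(CN(C)c3ccc4[nH]nc(C(=O)O)c4c3)c2)sc1C`, is the larger of the two, and in an assay on isolated protein for inhibition of 2-Hydroxyacid oxidase 1 (Homo sapiens), with stated times of 30 min and 15 min (a lower number here means a stronger inhibitor, a higher number a weaker inhibitor), compound 1 gives 290 nM. Within the data shown here, this is the only real number in the set. For compound 2, `CNc1ccc2[nH]nc(C(=O)O)c2c1`, the value > 30000 nM in this assay is a limit of the assay and not a number; it is the limit of > 30000 nM in this assay, at which 1 of the 2 values shown sits. Among the measured compounds shown here, compound 1 therefore stands as the one compound with a measured concentration, while compound 2 sits at the limit.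

Compound 3, `Cc1csc(-c2cccc(CN(C)c3ccc4[nH]nc(C(=O)O)c4c3)c2)n1`, is the next compound to be measured in this assay. It differs from compound 1 in one place: hydrogen in place of methyl on an aromatic carbon, so the 4,5-dimethyl-1,3-thiazol-2-yl group of compound 1 becomes 4-methyl-1,3-thiazol-2-yl. For the measured compounds named here, no step between measured compounds of this kind is available. The removal of a single methyl group is expected to change the number by a small step, if anything toward a weaker inhibitor, so that the step from compound 1 to compound 3 is estimated as a 1.6-fold higher number from compound 1 to compound 3 (0.19 log units; within the scatter), close to the scatter. Compound 3 is thus expected to give about 450 nM in this assay, estimated between 150 nM and 1400 nM.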

Compound 3, half-maximal inhibitory concentration: 650 nM
Beside the measured number, compound 3's estimate is 1.4-fold (0.16 log units) below it; low and high end bracket the measured number.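

In this assay, the change reads as a 2.2-fold higher number from compound 1 to compound 3 (0.35 log units; beyond the scatter). This gives the first measured sign that the methyl on the aromatic carbon next to the ring sulfur contributes to inhibition, though only modestly: the step lies beyond the scatter, but the 4-methyl-1,3-thiazol-2-yl group of compound 3 still gives a real number, 650 nM, and not a limit of the assay. Nothing among the results shown explains why losing this one methyl has that effect.

On these data alone, this position is known so far only through methyl and hydrogen, so it remains open whether a chlorine atom, an ethyl group or a methoxy group there would match compound 1, go beyond it or fall short of compound 3. As far as these compounds go, the other methyl on the ring, on the carbon next to the one that changed, also remains untested on its own, and a single step cannot show whether it would matter to the same degree or whether the two methyl groups act independently.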